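Moving a trifluoromethyl onto the aryl urea

This account rests on a few compounds, and the source may have more. Where it says the series, first, only, none or still open, it means among the compounds named here.

Three members of this series have been measured in a functional assay on MOLT-4 cells (Homo sapiens) for inhibition, read by MTT assay, with a stated time of 72 h; a lower number here means a stronger inhibitor, a higher number a weaker inhibitor. Compound 1 `COc1cc(NC(C)CCCNC(=O)NNC(=O)Nc2cccc(F)c2)c2ncccc2c1` reaches only a limit of the assay, giving >= 250000 nM in this assay (the limit of >= 250000 nM in this assay, at which 1 of the 3 values shown sits). Compound 2 `COc1cc(NC(C)CCCNC(=O)NNC(=O)Nc2cc(C(F)(F)F)cc(C(F)(F)F)c2)c2ncccc2c1` gives 22000 nM in this assay, and compound 3 `COc1cc(NC(C)CCCNC(=O)NNC(=O)Nc2ccc(Br)cc2)c2ncccc2c1` gives 209000 nM, the higher of the two numbers recorded. Among the measured compounds shown here, the one step between measured compounds that differ in a single place, an at least 1.1-fold lower number from compound 1 to compound 3 (0.07 log units; that floor lies within the scatter), is only a floor and lies within the scatter.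

Compound 4 `COc1cc(NC(C)CCCNC(=O)NNC(=O)Nc2cccc(C(F)(F)F)c2)c2ncccc2c1` is not yet measured. It differs from compound 3 in one place: 3-(trifluoromethyl)phenyl in place of 4-bromophenyl on an amide-type nitrogen. For the measured compounds named here, no measured step copies this change directly. Compound 2, which carries two trifluoromethyl groups on the same ring, gives a lower number than compound 3, so a move of the same kind, though of smaller size, is expected for compound 4. For compound 4 the expected step is a 2.6-fold lower number from compound 3 to compound 4 (0.42 log units; beyond the scatter). Compound 4 is therefore estimated at 80000 nM in this assay, within a range from 25000 nM to 250000 nM.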

Compound 4, half-maximal inhibitory concentration: 36000 nM
The estimate for compound 4 lay 2.2-fold (0.35 log units) above the measured number; measured number inside the range.
By their numbers in this assay, from the lowest: compounds 2 and 4 (each within the scatter of the next); then compound 3. At a limit, above all of these: compound 1.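

On this amide-type nitrogen, 3-(trifluoromethyl)phenyl in place of 4-bromophenyl gives a 5.8-fold lower number from compound 3 to compound 4 (0.76 log units; beyond the scatter) in this assay, while the second trifluoromethyl of compound 2 cannot be told apart from hydrogen, which gives a 1.6-fold higher number from compound 2 to compound 4 (0.21 log units; within the scatter). Trifluoromethyl in place of fluoro on an aromatic carbon gives an at least 6.9-fold lower number from compound 1 to compound 4 (0.84 log units; beyond the scatter), and this is only a floor on the size of that change. Compound 1 stands at a limit of the assay, not at a number: the limit of >= 250000 nM in this assay, at which 1 of the 4 values shown sits.

Compound 3 and compound 4 differ in both the substituent and its place on the ring, so the compounds shown do not tell which of the two carries the difference. They also leave open how a nitrile, a methoxy group or an amine on the same ring would compare.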